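A few compounds are considered here, and "the series" means these few. Any claim that something is new, unique, unknown or untested is made for them only; others in the source may bear on it.

In an ADME assay on NIH3T3 cells (Mus musculus) for cytotoxicity (a higher number here means that more compound is needed for the effect, a lower number that less compound is needed), two compounds have been tested so far. Compound 1 `Clc1ccc(Oc2cccc(Cn3ccnc3)c2)cc1` reads > 100000 nM, which is a limit of the assay and not a number. Among the measured compounds shown here, compound 2 `Cc1cc(Oc2cccc(Cn3ccnn3)c2)cc(C)c1Cl` gives 66800 nM, the only true number available, so its standing cannot be judged against a second measured value.

Compound 3 `Cc1nnc(Cc2cccc(Oc3cc(C)c(Cl)c(C)c3)c2)o1` keeps the shared core of compound 2 and differs in one place: 5-methyl-1,3,4-oxadiazol-2-yl in place of 1H-1,2,3-triazol-1-yl on a saturated chain carbon bound to an aromatic carbon. In words, 5-methyl-1,3,4-oxadiazol-2-yl stands in place of 1H-1,2,3-triazol-1-yl on a saturated chain carbon bound to an aromatic carbon. For the measured compounds named here, no measured pair isolates a change of this kind, and the group leaving and the group entering are each one five-membered aromatic ring. No shift beyond the usual scatter is therefore expected in this assay. The estimated step of a 1.0-fold higher number from compound 2 to compound 3 (0.02 log units; within the scatter) is expected to be small. For compound 3 the expected value is 70000 nM, with an estimated range of 30000 nM to 100000 nM.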

Compound 3, half-maximal effective concentration: 6200 nM
Compound 3: middle estimate off by 11-fold (1.05 log units), on the high side; the whole stated range lies above it.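

Among the compounds shown here, the exchange on the saturated chain carbon bound to an aromatic carbon gives the first readable step in this assay: 5-methyl-1,3,4-oxadiazol-2-yl in place of 1H-1,2,3-triazol-1-yl gives an 11-fold lower number from compound 2 to compound 3 (1.03 log units; beyond the scatter). This position is therefore sensitive to which five-membered aromatic ring it carries, even though the two groups have equal counts of hetero atoms, hydrogen-bond donors and hydrogen-bond acceptors. The change also moves the series further from the ceiling of the assay: the limit of > 100000 nM in this assay, at which 1 of the 3 values shown sits.

Going by these compounds, this single step cannot separate the added methyl group from the exchange of the ring itself, so it remains open how the unsubstituted 1,3,4-oxadiazol-2-yl would read. Also open, on these data alone, is how an amine or a carboxylic acid on the same chain carbon would read in this assay.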